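From naphthalen-2-yl to 3-hydroxy-4-methoxyphenyl on a shared core

A few compounds are considered here, and "the series" means these few. Any claim that something is new, unique, unknown or untested is made for them only; others in the source may bear on it.

Compound 1 `CCOC(=O)c1cc(-c2cc(OC)c(OC)c(OC)c2)c(-c2ccc(OC)c(O)c2)s1`: 1580 nM
Compound 2 `COc1cc(-c2cc(C(=O)O)sc2-c2ccc3ccccc3c2)cc(OC)c1OC`: 380 nM

In a functional assay on SGC-7901 cells (Homo sapiens) for antiproliferative activity, read by MTT assay, with a stated time of 72 h (on this read-out lower numbers stand for stronger inhibition and higher numbers for weaker inhibition), compound 2 gives 380 nM, the lower of the two numbers. Compound 1 gives 1580 nM, and that gap lies beyond the usual scatter.

Compound 3 `COc1ccc(-c2sc(C(=O)O)cc2-c2cc(OC)c(OC)c(OC)c2)cc1O` has not yet been measured. It differs from compound 2 in one place, next to the ring sulfur, where 3-hydroxy-4-methoxyphenyl stands in place of naphthalen-2-yl: 3-hydroxy-4-methoxyphenyl in place of naphthalen-2-yl on an aromatic carbon.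

Among the compounds with values here, no pair of measured compounds shows what this swap does, so any expectation is loose. Within the data shown here, the only other measured number, for compound 1 at 1580 nM, sits higher, so a moderate rise in this assay, meaning weaker inhibition, is expected. The estimated change is a 1.8-fold higher number from compound 2 to compound 3 (0.27 log units; within the scatter). For compound 3 the expected value is 700 nM, with an estimated range from 150 nM to 3000 nM.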

Compound 3, half-maximal inhibitory concentration: 6100 nM
For compound 3 the middle estimate is 8.7-fold (0.94 log units) below the measured one; the whole stated range lies below it.
By their numbers in this assay, from the lowest: compound 2; then compound 1; then compound 3.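

In this assay, the position next to the ring sulfur proves sensitive: 3-hydroxy-4-methoxyphenyl in place of naphthalen-2-yl gives a 16-fold higher number from compound 2 to compound 3 (1.21 log units; beyond the scatter) and so a large loss of inhibition on the shared core. The group on the oxygen next to a carbonyl group also counts, as hydrogen in place of ethyl gives a 3.9-fold higher number from compound 1 to compound 3 (0.59 log units; beyond the scatter) and a more modest loss. Nothing measured here bears on why either step occurs.

The swap from naphthalen-2-yl removes an aromatic ring and brings in the hydroxy and methoxy groups at once, so these compounds cannot show which of these changes matters. From the compounds shown here alone, a plain phenyl group at this position would help separate them, and it remains open whether ethyl in place of hydrogen would shift compound 2 as it does compound 3.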